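The source may hold more compounds than are shown below. What is called first, only, known or untested is meant among the compounds shown, and "the series" means these compounds.

In a functional assay on HepG2 cells (Homo sapiens) for antiproliferative activity, read by MTT assay, with a stated time of 72 h (a higher number here means a weaker inhibitor, a lower number a stronger inhibitor), compound 1 `COc1ncc(-c2ccc3c(c2)N(c2ccc(C)cc2)C(=O)CO3)cc1NS(=O)(=O)c1ccc(F)cc1` gives 28300 nM. Compound 3 `COc1ccc(N2C(=O)COc3ccc(-c4ccc(O)cc4)cc32)cc1` gives 10800 nM, a lower number by more than the usual scatter, which makes compound 1 the weaker inhibitor of this pair. Compound 2 `O=C1COc2ccc(-c3cnc(Cl)c(NS(=O)(=O)c4ccc(F)cc4)c3)cc2N1C1CCCCC1` gives no number, only a limit of the assay, > 40000 nM. Compound 1 therefore holds the higher of the two true numbers, and all three compounds are measured only at high concentrations.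

The unmeasured compound 4 `COc1ncc(-c2ccc3c(c2)N(c2ccc(F)cc2)C(=O)CO3)cc1NS(=O)(=O)c1ccc(F)cc1` differs from compound 1 in one place: fluoro in place of methyl on an aromatic carbon. The change lies on a six-membered aromatic ring of carbon only, para to a large group, so that 4-methylphenyl becomes 4-fluorophenyl. The rest of the molecule stays the same.

For the measured compounds named here, no pair of measured compounds here differs in just one place, so the data give no direct guide to the size or direction of this change. The expectation therefore starts from compound 1 at 28300 nM and assumes no shift beyond the scatter in this assay. The expected step of a 1.1-fold lower number from compound 1 to compound 4 (0.05 log units; within the scatter) is small. Compound 4 is estimated at 25000 nM, with an expected range from 12000 nM to 40000 nM.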

Compound 4, half-maximal inhibitory concentration: 36400 nM
Beside the measured number, compound 4's estimate is 1.5-fold (0.16 log units) below it; measured number inside the range.
By their numbers in this assay, from the lowest: compound 3; then compounds 1 and 4 (each within the scatter of the next). At a limit, above all of these: compound 2.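

For the compounds shown here, compound 1 and compound 4 form the first measured pair here that differs in only one place, so this position can now be read directly rather than assumed. In this assay, placing fluoro instead of methyl on the aromatic carbon, which turns 4-methylphenyl into 4-fluorophenyl, gives a 1.3-fold higher number from compound 1 to compound 4 (0.11 log units; within the scatter), so this read-out does not separate the two groups at this position. Room to read further changes at the weak end of the scale is short, as compound 2 gives only a limit and not a number: the limit of > 40000 nM in this assay, at which 1 of the 4 values shown sits.

From the compounds shown here alone, whether an amine, a carboxylic acid or a longer chain at this position would move the number beyond the scatter remains open, since a swap between two single-atom groups tests only a narrow part of what could sit there. Also open, going by these compounds, is whether the same swap would give an equally small step when the rest of the molecule is different, as a single pair cannot show how far this result carries.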